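The compounds below may be only part of what the source reports. "The series", "measured", "known", "first", "only" and "open" are said of these compounds alone.

Of the compounds shown here, two of this study have been measured in an assay on isolated protein for binding affinity to prostaglandin D2 receptor (Mus musculus); on this read-out higher numbers stand for weaker inhibition and lower numbers for stronger inhibition. Compound 1, `CCCCOc1cccc(C(=O)n2c(C)c(CC(=O)O)c3cc(OC)ccc32)c1`, gives 410 nM. Compound 2, `CCCCOc1ccc(C(=O)n2c(C)c(CC(=O)O)c3cc(OC)ccc32)cc1`, gives 270 nM. Of the two numbers, that of compound 2 is the lower, but the gap to compound 1 lies within the scatter, so the two cannot be ranked against each other.

The step to be followed leads from compound 2 to compound 3, `CCCCOc1ccc(C(=O)n2c(C)c(CCCCC(=O)O)c3cc(OC)ccc32)cc1`. The difference is 3-carboxypropyl in place of carboxy on a saturated chain carbon bound to an aromatic carbon: the acid is no longer held close to the shared core but carried out on a longer chain. Within the data shown here, no step between measured compounds in this assay shows what such a change does, so the expectation rests on the structural change alone rather than on a measured precedent. The expected direction in this assay is toward a higher number, a step beyond the scatter. Among the measured compounds shown here, the acid is the one group that the two measured compounds share unchanged, and this change moves it far from the core.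

For compound 3 the estimate in this assay is 4000 nM, with a range from 800 nM to 20000 nM, which corresponds to an expected step of a 15-fold higher number from compound 2 to compound 3 (1.17 log units; beyond the scatter).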

Compound 3, inhibition constant: 400 nM
The estimate for compound 3 lay 10-fold (1.00 log units) above the measured number; measured number outside the range, below it.
By their numbers in this assay, from the lowest: compounds 2, 3 and 1 (each within the scatter of the next).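

In this assay, putting 3-carboxypropyl in place of carboxy on a saturated chain carbon bound to an aromatic carbon gives a 1.5-fold higher number from compound 2 to compound 3 (0.17 log units; within the scatter), so the two compounds cannot be told apart. Among these compounds, this is the first view of this position, since the earlier pair shares the acid-bearing chain unchanged and differs only elsewhere. Read one bond further out, as carboxymethyl to 4-carboxybutyl, the result shows that for this pair the acid can sit much further out from the shared core with no readable difference in the number, and no supporting measurement is available to account for this.

Still open, as far as these compounds go, is whether the carboxylic acid itself matters at the end of the longer chain, a question that a primary amide or a methyl ester in its place would address. Among the compounds shown here, also open is how far this holds for other chain lengths, such as a 2-carboxyethyl group or a chain longer than 4-carboxybutyl, since one pair gives only a single comparison at this position.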